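The source may hold more compounds than are shown below. What is called first, only, known or untested is meant among the compounds shown, and "the series" means these compounds.

Working notes on the series.

Two compounds of the shared core carry a number or a remark. Compound 1 `COC(=O)c1cccc(-c2ccc([C@H]3S[C@@H](C)C(=O)Nc4c3c(C)nn4-c3ccccc3C)cc2)c1` is reported in an assay on isolated protein for agonist activity at Bile acid receptor (Homo sapiens), read by AlphaScreen, with a stated time of 30 min (on this read-out lower numbers stand for an effect already at smaller amounts and higher numbers for an effect only at larger amounts of compound), as "not active" (no number reported), so no value stands against it. Within the data shown here, compound 2 `CCOc1cccc(-c2ccc([C@H]3S[C@@H](C)C(=O)Nc4c3c(C)nn4-c3ccccc3C)cc2)c1` gives in this assay a half-maximal effective concentration of 3500 nM; it is the only entry of the series with a number, the one further entry being compound 1 without one. Among the measured compounds shown here, compound 2 therefore stands alone as the reference point, and no step between measured compounds can be drawn.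

Compound 3 `Cc1ccccc1-n1nc(C)c2c1NC(=O)[C@H](C)S[C@@H]2c1ccc(Oc2cccc(C(=O)O)c2)cc1` is the next to be measured in this assay. Its change from compound 2 is 3-carboxyphenoxy in place of 3-ethoxyphenyl on an aromatic carbon, on an aromatic carbon of a six-membered aromatic ring of carbon only. With the 3-carboxyphenoxy group bringing one hydrogen-bond donor and two hydrogen-bond acceptors where the 3-ethoxyphenyl had none and one, and with only the number of compound 2 to go by, the expectation is a modest step toward lower concentration, a 2.3-fold lower number from compound 2 to compound 3 (0.37 log units; beyond the scatter), though a result no further than the scatter would not surprise. For compound 3 the estimate in this assay is 1500 nM, with a range from 300 nM to 8000 nM.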

Compound 3, half-maximal effective concentration: "not active" (no number reported)
For compound 3 the study gives words and no number, so the estimate cannot be set against anything.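

In this assay, among these compounds, compound 3 is reported as "not active" (no number reported), so no step from compound 2 can be read, and compound 2 at 3500 nM remains the only number. Nothing available bears on this result.

The compounds shown leave open how any change at this place would shift the number of compound 2.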